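Swapping Methyl for Cyano in Compound 3

The compounds below may be only part of what the source reports. "The series", "measured", "known", "first", "only" and "open" are said of these compounds alone.

Among the measured compounds shown here, only two compounds have numbers so far in a functional assay on a cell-free system (plasma, Oryctolagus cuniculus) for inhibition, with stated times of 5 min, 1 min and 6 min (a lower number here means a stronger inhibitor, a higher number a weaker inhibitor), and they sit level with each other. Compound 1 `Cc1nc(-c2cccc(C#N)c2)n(OCc2ccccc2)c1C(=O)O` gives 6240 nM there. Compound 2 `Cc1ccc(COn2c(-c3cccc(C#N)c3)nc(C)c2C(=O)O)cc1` gives 6560 nM on the same scale, so the two cannot be told apart. The next compound, compound 3 `Cc1nc(-c2cccc(C#N)c2)n(OCc2ccc(C#N)cc2)c1C(=O)O`, keeps all of compound 2 except one group: cyano in place of methyl on an aromatic carbon, para to a large group, turning 4-methylbenzyl into 4-cyanobenzyl (cyano in place of methyl on an aromatic carbon). For the measured compounds named here, one measured step touches that same carbon, and it stays within the scatter (a 1.1-fold higher number from compound 1 to compound 2 (0.02 log units; within the scatter)). Going by the values given here, that step swaps hydrogen for methyl, so it is thin evidence for a cyano group, and no measured compound here carries cyano at this carbon. On this slim basis, no step beyond the scatter is expected in this assay, and no direction can be favoured. The estimated step is accordingly small (a 1.1-fold lower number from compound 2 to compound 3 (0.04 log units; within the scatter)). Compound 3 is expected to give about 6000 nM as a value, with an estimated range from 2800 nM to 13000 nM as its ends.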

Compound 3, half-maximal inhibitory concentration: 3880 nM
Compound 3: the middle estimate sits 1.5-fold (0.19 log units) above what was measured; low and high end bracket the measured number.
By their numbers in this assay, from the lowest: compounds 3, 1 and 2 (each within the scatter of the next).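

With compound 3, this aromatic carbon has now been seen carrying cyano as well as methyl and hydrogen, and in this assay the change from methyl to cyano reads as a 1.7-fold lower number from compound 2 to compound 3 (0.23 log units; within the scatter). Set against compound 1, which has only hydrogen on this carbon, the same cyano group reads as a 1.6-fold lower number from compound 1 to compound 3 (0.21 log units; within the scatter), so neither methyl nor cyano takes the number beyond the usual scatter of repeated measurements, even though cyano brings one more heavy atom and a hydrogen-bond acceptor that methyl lacks. No supporting measurement ties these small steps to any cause.

Still open, from the compounds shown here alone, is whether this carbon tolerates any group at all without a real change in the number, since an amine, a hydroxyl or a longer chain placed here might give a step beyond the scatter where hydrogen, methyl and cyano do not. The compounds shown also leave open whether cyano would behave the same way on the other carbons of this ring, as all of the changes so far sit on one carbon.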